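Stereoisomer of compound 2: two centres inverted

This account rests on a few compounds, and the source may have more. Where it says the series, first, only, none or still open, it means among the compounds named here.

Compounds measured:
compound 1 `COc1cccc(/C=C/C[C@@H]2C[C@@H]([C@@H](O)c3ccc(OC)c(OC)c3)CO[C@H]2c2ccc(OC)c(OC)c2)c1`: 16400 nM
compound 2 `COc1ccc(/C=C/C[C@@H]2C[C@@H]([C@@H](O)c3ccc(OC)c(OC)c3)CO[C@H]2c2ccc(OC)c(OC)c2)cc1OC`: 30600 nM
compound 3 `COc1cccc([C@@H]2OC[C@H]([C@@H](O)c3ccc(OC)c(OC)c3)C[C@H]2C/C=C/c2ccc(OC)c(OC)c2)c1`: 30100 nM

In a functional assay on HeLa cells (Homo sapiens) for cytotoxicity, read by WST assay, with a stated time of 48 h (on this read-out higher numbers stand for weaker inhibition and lower numbers for stronger inhibition), compound 2 gives 30600 nM and compound 3 gives 30100 nM. The three numbers lie within the scatter of one another: the step of a 1.9-fold higher number from compound 1 to compound 2 (0.27 log units; within the scatter) and the step of a 1.0-fold lower number from compound 2 to compound 3 (0.01 log units; within the scatter) are both too small to read as real changes, so compound 2 is indistinguishable from its neighbours on this read-out.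

Compound 4 `COc1ccc(/C=C/C[C@@H]2C[C@H]([C@H](O)c3ccc(OC)c(OC)c3)CO[C@H]2c2ccc(OC)c(OC)c2)cc1OC` differs from compound 2 as follows: the two compounds have the same atoms and bonds and differ only in configuration as drawn: 2 of 5 stereo elements differ; a stereocentre at a saturated ring carbon is drawn R in compound 2 and S in compound 4; a stereocentre at a saturated chain carbon is drawn R in compound 2 and S in compound 4. Neither measured step concerns configuration; both concern a methoxy group, so nothing here speaks directly to the change. The estimate for compound 4 therefore rests on compound 2 alone and is expected to come out as a 1.0-fold lower number from compound 2 to compound 4 (0.01 log units; within the scatter), with wide uncertainty.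

Compound 4 is expected to give about 30000 nM in this assay, within 10000 nM to 90000 nM.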

Compound 4, half-maximal inhibitory concentration: 28700 nM
Beside the measured number, compound 4's estimate is 1.0-fold (0.02 log units) above it; low and high end bracket the measured number.
By their numbers in this assay, from the lowest: compounds 1, 4, 3 and 2 (each within the scatter of the next).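

In this assay, the series now has a step that concerns configuration rather than a methoxy group: a 1.1-fold lower number from compound 2 to compound 4 (0.03 log units; within the scatter). Inverting the saturated ring carbon and the saturated chain carbon together produces no readable change on this read-out. This step can be read as one of configuration alone because nothing else separates the pair: the fact that compounds 2 and 4 differ only in the configuration as drawn

As far as these compounds go, whether inverting either centre alone, or the other three stereo elements, would behave the same way remains open. So does whether an amine or a carboxylic acid in place of a methoxy group would shift the number.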